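Two Quinoline Cores, One Halogen Swap on HT-29

The source may hold more compounds than are shown below. What is called first, only, known or untested is meant among the compounds shown, and "the series" means these compounds.

Measured so far:
compound 1 `Cc1ccc2nc(-c3ccc(Cl)cc3)cc(C(=O)OCc3ccccc3)c2c1` — > 100000 nM
compound 2 `Cc1ccc2nc(-c3ccc(F)cc3)cc(C(=O)OCc3ccccc3)c2c1` — 15100 nM
compound 3 `Cc1ccc2nc(-c3ccc(Cl)cc3)cc(COCc3ccccc3)c2c1` — > 100000 nM

In a functional assay on HT-29 cells (Homo sapiens) for antiproliferative activity, read by MTT assay, with a stated time of 48 h (a higher number here means a weaker inhibitor, a lower number a stronger inhibitor), compound 1 reaches only the limit of > 100000 nM, which is a limit of the assay and not a number. Compound 2 differs from it by fluoro in place of chloro on an aromatic carbon and gives 15100 nM in this assay, so the step is an at least 6.6-fold lower number from compound 1 to compound 2 (0.82 log units; beyond the scatter). Compound 3 carries a different core; how the two cores differ is not broken down here. For compound 3 this assay gives only the limit > 100000 nM, and the limit of > 100000 nM in this assay, at which 2 of the 3 values shown sit, applies to both it and compound 1.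

Compound 4 `Cc1ccc2nc(-c3ccc(F)cc3)cc(COCc3ccccc3)c2c1` is not yet measured. It differs from compound 3 by fluoro in place of chloro on an aromatic carbon, the same change seen between compounds 1 and 2. As compound 3 sits at the limit, the earlier step can only be read as a direction. Compound 4 is expected to show a step of an at least 2.5-fold lower number from compound 3 to compound 4 (0.39 log units; beyond the scatter) in this assay, resting on compound 2 reaching 15100 nM after the same swap. For compound 4 the estimate is 40000 nM, between 10000 nM and 150000 nM.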

Compound 4, half-maximal inhibitory concentration: > 100000 nM
Compound 4 ended at the assay's limit (the forecaster's own chance of this, stated with the estimate: 45%); middle value at least 2.5-fold (0.39 log units) from the limit.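

Compound 3 and compound 4 both stand at a limit in this assay, so no step can be read between them: the limit of > 100000 nM in this assay, at which 3 of the 4 values shown sit.

The compounds shown leave open whether the change from 4-chlorophenyl to 4-fluorophenyl has any effect on the number on the core of compound 3, as it does on the core of compound 1.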